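Swapping the nitrogen substituent on a charged core

This account rests on a few compounds, and the source may have more. Where it says the series, first, only, none or still open, it means among the compounds named here.

Measured compounds:
compound 1, `CCN1CCc2c(sc(NC(=S)Nc3ccc(Cl)cc3)c2C(N)=O)C1`, 6570 nM
compound 2, `CC(C)[N+]1(C)CCc2c(sc(NC(=O)Nc3ccc(Cl)cc3)c2C(N)=O)C1`, 960 nM
compound 3, `COCCCN1CCc2c(sc(NC(=O)Nc3ccc(Cl)cc3)c2C(N)=O)C1`, 2400 nM

In a functional assay (strain AB) with Danio rerio as the target, read by microscopy, with a stated time of 1 h (a higher number here means that more compound is needed for the effect, a lower number that less compound is needed), compound 2 gives 960 nM, the lowest of the three numbers. Compound 3 gives 2400 nM, a gap beyond the scatter, and compound 1 gives 6570 nM, the widest gap. Compound 2 therefore stands apart as the one needing the least compound among these three.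

The next compound, compound 4, `COCCC[N+]1(C)CCc2c(sc(NC(=O)Nc3ccc(Cl)cc3)c2C(N)=O)C1`, is not yet measured in this assay. It differs from compound 2 in one place: 3-methoxypropyl in place of isopropyl on an amine nitrogen in a ring.

Among the compounds with values here, no step between two measured compounds isolates this change, so the size of its effect is open. Compound 3, which also carries 3-methoxypropyl on that nitrogen, sits above compound 2, but it differs from compound 4 elsewhere as well. The expectation is a step from compound 2 to compound 4 of a 1.4-fold higher number from compound 2 to compound 4 (0.13 log units; within the scatter), a small rise lying within the scatter. Compound 4 is therefore estimated at 1300 nM, with a range from 500 nM to 3500 nM.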

Compound 4, half-maximal effective concentration: 480 nM
The estimate for compound 4 lay 2.7-fold (0.43 log units) above the measured number; measured number below the stated range.
By their numbers in this assay, from the lowest: compounds 4 and 2 (each within the scatter of the next); then compound 3; then compound 1.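

In this assay, within the data shown here, this is the first step that isolates the group on the ring nitrogen of the charged core: a 2.0-fold lower number from compound 2 to compound 4 (0.30 log units; within the scatter). Isopropyl and 3-methoxypropyl therefore cannot be told apart at this position, even though the entering group has more heavy atoms and adds an oxygen and a hydrogen-bond acceptor. On this core, then, the chain on that nitrogen can be lengthened and can carry an ether oxygen with no change beyond the scatter, and compound 4 gives 480 nM, in the same range as compound 2.

As far as these compounds go, whether this holds for a longer chain, or for a chain ending in an amine or a carboxylic acid, remains open. Nothing shown explains why the two groups read alike.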